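A few compounds are considered here, and "the series" means these few. Any claim that something is new, unique, unknown or untested is made for them only; others in the source may bear on it.

For the measured compounds named here, in a functional assay on MCF7 cells (Homo sapiens) for antiproliferative activity, read by CCK-8 assay, with a stated time of 48 h (on this read-out higher numbers stand for weaker inhibition and lower numbers for stronger inhibition), compound 1 (`O=C(/C=C/CNCCOc1ccc(Oc2c(-c3ccc(F)cc3)sc3cc(O)ccc23)cc1)N1CCCC1`) gives 7610 nM and compound 2 (`C=CC(=O)NCCOc1ccc(Oc2c(-c3ccc(F)cc3)sc3cc(O)ccc23)cc1`) gives 23000 nM on the shared core, and a 3.0-fold higher number from compound 1 to compound 2 (0.48 log units; beyond the scatter) is the only measured step beyond the scatter. Compound 3 (`CN(C)C(=O)/C=C/CNCCOc1ccc(Oc2c(-c3ccc(F)cc3)sc3cc(O)ccc23)cc1`) gives 13800 nM and stands within the scatter of both others, as a 1.8-fold higher number from compound 1 to compound 3 (0.26 log units; within the scatter) and a 1.7-fold lower number from compound 2 to compound 3 (0.22 log units; within the scatter) show. Compound 4 (`C/C=C/C(=O)NCCOc1ccc(Oc2c(-c3ccc(F)cc3)sc3cc(O)ccc23)cc1`) arises from compound 3 through (prop-1-en-1-yl)carbonyl in place of 3-(dimethylcarbamoyl)prop-2-en-1-yl on an amine nitrogen and so has (prop-1-en-1-yl)carbonyl where compound 2 has vinylcarbonyl on the amine nitrogen. Going by the values given here, no measured compound carries the (prop-1-en-1-yl)carbonyl group itself. The closest guide is the step of a 1.7-fold lower number from compound 2 to compound 3 (0.22 log units; within the scatter) read in reverse, since it exchanges the same 3-(dimethylcarbamoyl)prop-2-en-1-yl for vinylcarbonyl, and the larger 3.0-fold higher number from compound 1 to compound 2 (0.48 log units; beyond the scatter) points the same way. The expected step is a 1.4-fold higher number from compound 3 to compound 4 (0.16 log units; within the scatter) and this small rise is not expected to pass beyond the scatter. For compound 4 the estimate is 20000 nM with an expected range from 10000 nM to 40000 nM in this assay once it is measured.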

Compound 4, half-maximal inhibitory concentration: 21700 nM
Compound 4: middle estimate off by 1.1-fold (0.04 log units), on the low side; the measured number falls inside the stated range.
By their numbers in this assay, from the lowest: compounds 1, 3, 4 and 2 (each within the scatter of the next, the first and the last beyond it).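

On the carbonyl carbon, prop-1-en-1-yl in place of vinyl leaves the antiproliferative read-out within the scatter (a 1.1-fold lower number from compound 2 to compound 4 (0.03 log units; within the scatter)), so the two groups cannot be told apart here. The new (prop-1-en-1-yl)carbonyl group on the amine nitrogen also stays within the scatter of the 3-(dimethylcarbamoyl)prop-2-en-1-yl group of compound 3 (a 1.6-fold higher number from compound 3 to compound 4 (0.20 log units; within the scatter)), yet it gives a second step beyond the scatter from the 3-((pyrrolidin-1-yl)carbonyl)prop-2-en-1-yl group (a 2.9-fold higher number from compound 1 to compound 4 (0.46 log units; beyond the scatter)), as vinylcarbonyl did. No measurement at hand explains these results.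

Going by these compounds, whether a propanoyl group, which has no double bond outside aromatic rings, would read like vinylcarbonyl on the amine nitrogen remains open. So does how a piperidin-1-yl or morpholin-4-yl group would compare with pyrrolidin-1-yl on the carbonyl carbon.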